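Nitro for Methoxy on the Benzamide Ring

The source may report more compounds than this note shows. Statements on the series, on what has been measured and on what is new or still open speak of the compounds shown alone.

Measured in a functional assay on the whole organism (strain albino) for inhibition, with Rattus norvegicus as the target, read by paw edema, with stated times of 30 min and 3 h, at a dose of 5 mg/kg by the oral route; a higher number here means more inhibition at the dose given (going by the name of the read-out), a lower number less inhibition:
Compound 1 `CCOC(=O)Cc1n[nH]c(NC(=O)c2ccccc2)n1`: 55.3%
Compound 2 `CCOC(=O)Cc1n[nH]c(NC(=O)c2ccc(OC)cc2)n1`: 56%

For the measured compounds named here, compound 2 sits at the top of these two numbers, yet compound 1, its only neighbour, lies within the scatter of it. Compound 3 `CCOC(=O)Cc1n[nH]c(NC(=O)c2ccc([N+](=O)[O-])cc2)n1` differs from compound 2 by nitro in place of methoxy on an aromatic carbon. Going by the values given here, the one measured step that bears on this, a number 0.7 percentage points higher from compound 1 to compound 2 (within the scatter), also swapped a group on an aromatic carbon and left the paw-edema inhibition essentially unchanged. Nothing here shows that a nitro group would behave differently, so the expected step of a number 1 percentage points lower from compound 2 to compound 3 (within the scatter) in this assay is none beyond the scatter. Compound 3 is therefore estimated at 55%, with a range from 42% to 68%.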

Compound 3, a percentage reported as inhibition, in the whole organism at one dose (the size of the read-out at that dose, not a potency): 59.8%
Compound 3: the middle estimate sits 4.8 percentage points below what was measured; measured number inside the range.
By their numbers in this assay, from the lowest: compounds 1, 2 and 3 (each within the scatter of the next).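

In this assay, nitro at this aromatic carbon gives a number 3.8 percentage points higher from compound 2 to compound 3 (within the scatter) and, set against hydrogen, a number 4.5 percentage points higher from compound 1 to compound 3 (within the scatter). Hydrogen, methoxy and nitro at this position therefore all lie within the scatter of one another, so even the entering group with the most heavy atoms and hydrogen-bond acceptors shifts the inhibition at this dose by no more than the scatter. No measurement here accounts for this flat result. Still open, going by these compounds, is whether an amine or a carboxylic acid at this same carbon would move the inhibition beyond the scatter.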